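Compound 4 against the limit of compound 1

The compounds below may be only part of what the source reports. "The series", "measured", "known", "first", "only" and "open" are said of these compounds alone.

In a functional assay on HT-29 cells (Homo sapiens) for inhibition, read by sulforhodamine B assay, with a stated time of 48 h (on this read-out higher numbers stand for weaker inhibition of growth and lower numbers for stronger inhibition of growth), compound 1 (`S=C(N/N=C/c1cccs1)Nc1ccc(Cl)cc1`) gives > 100000 nM as a limit of the assay. Compound 2 (`S=C(N/N=C/c1cccs1)Nc1cccc2ccccc12`) gives > 100000 nM as a limit too. Compound 3 (`COc1ccc(NC(=S)N/N=C/c2cccs2)cc1`) gives > 100000 nM as a limit too. Compound 1 therefore stands at the limit of > 100000 nM in this assay, at which 3 of the 3 values shown sit, and has no readable rank. Compound 4 (`CCc1ccc(NC(=S)N/N=C/c2cccs2)cc1`) differs from compound 1 by ethyl in place of chloro on an aromatic carbon in the form of ethyl in place of chloro on an aromatic carbon, para to a large group. For the measured compounds named here, the one measured step at that place, methoxy in place of chloro, is a step that the two limits leave unreadable from compound 1 to compound 3 and gives neither size nor direction, so no step beyond the scatter is expected in this assay for compound 4. The expected step is a number no higher from compound 1 to compound 4 (the limit leaves the size open) as estimated here. Compound 4 is expected at 100000 nM with an estimated range from 40000 nM to 200000 nM and may well return only a limit.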

Compound 4, concentration for 50% growth inhibition: > 100000 nM
Compound 4 ended at the assay's limit (the forecaster's own chance of this, stated with the estimate: 80%); the middle value lies on the limit itself.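

No step can be read among compound 1, compound 3 and compound 4, because all remain at a limit of the assay: the limit of > 100000 nM in this assay, at which 4 of the 4 values shown sit. The compounds shown leave open which change to the shared core, if any, would give a readable value.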